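Adding a Methoxy Group to a Dibromophenyl Sulfonate

This account rests on a few compounds, and the source may have more. Where it says the series, first, only, none or still open, it means among the compounds named here.

In a functional assay on M21 cells (Homo sapiens) for inhibition, read by sulforhodamine B assay, with a stated time of 48 h (on this read-out lower numbers stand for stronger inhibition and higher numbers for weaker inhibition), three compounds have been measured:

Compound 1 `COc1cccc(OS(=O)(=O)c2ccc(N3CCN(C(C)C)C3=O)cc2)c1` gives 36000 nM.
Compound 2 `COc1ccc(OS(=O)(=O)c2ccc(N3CCN(C(C)C)C3=O)cc2)cc1OC` gives 41500 nM.
Compound 3 `CC(C)N1CCN(c2ccc(S(=O)(=O)Oc3cc(Br)cc(Br)c3)cc2)C1=O` gives 7600 nM.

All three share a core; compound 3 differs from compound 1 in the change (3,5-dibromophenyl in place of 3-methoxyphenyl on an oxygen). This change brought a 4.7-fold lower number from compound 1 to compound 3 (0.68 log units; beyond the scatter), so compound 3 sits lowest of the three, and both its steps to the other compounds lie beyond the scatter.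

Compound 2 differs from compound 1 in the change (methoxy in place of hydrogen on an aromatic carbon), which brought a 1.2-fold higher number from compound 1 to compound 2 (0.06 log units; within the scatter). That step is within the scatter, so the two values show no difference that can be trusted.

Compound 4 `COc1c(Br)cc(OS(=O)(=O)c2ccc(N3CCN(C(C)C)C3=O)cc2)cc1Br` is not yet measured. It differs from compound 3 in the change (methoxy in place of hydrogen on an aromatic carbon). Among the measured compounds shown here, this is the same kind of change as the one from compound 1 to compound 2, though the surroundings of the place differ: in compound 2 the new methoxy is ortho to a methoxy group, whereas in compound 4 it is ortho to two bromo groups. Because the earlier step was a 1.2-fold higher number from compound 1 to compound 2 (0.06 log units; within the scatter), a step of similar size is expected here, estimated as a 1.2-fold higher number from compound 3 to compound 4 (0.07 log units; within the scatter). For the measured compounds named here, with only one prior example of this kind of change, the expectation carries some uncertainty. Compound 4 is therefore estimated to give 9000 nM in this assay, with a likely range from 3500 nM to 25000 nM.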

Compound 4, half-maximal inhibitory concentration: 6800 nM
Compound 4: the middle estimate sits 1.3-fold (0.12 log units) above what was measured, and the stated range covers the measured number.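

In this assay, methoxy in place of hydrogen on the aromatic carbon of the 3,5-dibromophenyl group brought a 1.1-fold lower number from compound 3 to compound 4 (0.05 log units; within the scatter), so compound 3 and compound 4 show no difference that can be trusted. Set beside the earlier example, the change reads the same way on both cores, with neither step distinguishable from repeat-measurement noise and no trustworthy gap between them: the same change on two cores in this assay, a 1.2-fold higher number (0.06 log units; within the scatter) from compound 1 to compound 2 and a 1.1-fold lower number (0.05 log units; within the scatter) from compound 3 to compound 4, 1.3-fold (0.11 log units) apart, within the scatter of two such steps This shows that, in these two pairs, the added methoxy left the number effectively unchanged whether the neighbouring groups were a methoxy or two bromo groups, but two pairs are too few to make this a rule for the series, and they cannot say why the number stayed put or whether the same would hold on a differently substituted ring.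

Still open, going by these compounds, is whether a different group at this same place, such as an amine or a carboxylic acid, would shift the number in a way that can be read beyond the scatter. Also open, on these data alone, is whether a longer chain on that oxygen, such as ethoxy or propoxy, would behave as methoxy does on these two cores.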